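The source may hold more compounds than are shown below. What is called first, only, known or untested is meant among the compounds shown, and "the series" means these compounds.

Measured in an ADME assay on BJ cells (Homo sapiens) for cytotoxicity, with a stated time of 72 h; on this read-out higher numbers stand for an effect only at larger amounts of compound and lower numbers for an effect already at smaller amounts:

- Compound 1 `C=C[C@@](C)(/C=C/c1ccc(O)cc1)CCCO`: > 36600 nM (a limit)
- Compound 2 `C=C[C@@](C)(/C=C/c1ccc(O)cc1)CC/C=C/C(=O)c1ccccc1`: > 36600 nM (a limit)

Compound 2 has no exact value on this read-out. Its result of > 36600 nM is a limit of the assay and not a number. Both measured compounds stand at the limit of > 36600 nM in this assay, at which 2 of the 2 values shown sit, so neither can be ranked against the other.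

The next compound keeps the shared core and changes one group. Compound 3 `C=C[C@@](C)(/C=C/c1ccc(O)cc1)CC/C=C/C#N` carries cyano in place of benzoyl on a double-bonded chain carbon bound to a double-bonded chain carbon. This swap removes the ring of the benzoyl group and leaves a much smaller group in its place.

Among the compounds with values here, no measured step between related compounds is available to show how large such a change might be in this assay. The expectation therefore rests on compound 2 at > 36600 nM. The expected a number no higher from compound 2 to compound 3 (the limit leaves the size open) is no larger than the usual scatter, with no clear direction, and a further limit is the most likely result. For compound 3 the estimated value is 36600 nM, with an expected range from 15000 nM to 60000 nM.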

Compound 3, half-maximal effective concentration: > 36600 nM
Compound 3: a limit, no number; the forecaster's own chance of this, stated with the estimate: 75%; the middle value lies on the limit itself.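

In this assay compound 3 gives > 36600 nM, which is a limit and not a number. The steps from compound 1 and compound 2 to compound 3 cannot be read, because all three compounds sit at the same limit: the limit of > 36600 nM in this assay, at which 3 of the 3 values shown sit.

The compounds shown leave open whether cyano in place of benzoyl changes this read-out at all, and how the three compounds rank.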